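Thiophene in place of hydroxymethylphenyl: expected cytotoxicity

This account rests on a few compounds, and the source may have more. Where it says the series, first, only, none or still open, it means among the compounds named here.

Compound 3 `O=[N+]([O-])c1c(CS(=O)(=O)c2ccccc2)nc2c(-c3ccccc3CO)cc(Cl)cn12` is the only one of the three measured compounds whose reading in an ADME assay on HepG2 cells (Homo sapiens) for cytotoxicity, read by MTT assay, with a stated time of 72 h (on this read-out higher numbers stand for lower toxicity in this test and lower numbers for higher toxicity in this test), is a number: compound 3 gives 88000 nM. For compound 1 `O=[N+]([O-])c1c(CS(=O)(=O)c2ccccc2)nc2c(-c3ccc(O)cc3)cc(Cl)cn12` the reading is only a limit of the assay, > 12500 nM. For compound 2 `O=[N+]([O-])c1c(CS(=O)(=O)c2ccccc2)nc2c(-c3cccc(CO)c3)cc(Cl)cn12` the reading is likewise a limit of the assay, > 25000 nM. Given the limit of > 12500 nM in this assay, at which 1 of the 3 values shown sits, and (the limit of > 25000 nM in this assay, at which 1 of the 3 values shown sits), the step that the limit leaves unreadable from compound 1 to compound 3, the step that the limit leaves unreadable from compound 2 to compound 3 and the step that the two limits leave unreadable from compound 1 to compound 2 cannot be read for size. Compound 4 `O=[N+]([O-])c1c(CS(=O)(=O)c2ccccc2)nc2c(-c3cccs3)cc(Cl)cn12` differs from compound 3 in one place: thiophen-2-yl in place of 2-(hydroxymethyl)phenyl on an aromatic carbon. Going by the values given here, no measured step bears readably on this change, so no step beyond the scatter in this assay is expected from compound 3 to compound 4. The estimated step is a 1.5-fold lower number from compound 3 to compound 4 (0.17 log units; within the scatter). Compound 4 is therefore expected to give about 60000 nM in this assay, within a range from 15000 nM to 200000 nM.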

Compound 4, half-maximal cytotoxic concentration: > 3900 nM
Compound 4 was reported as a limit; the forecaster's own chance of this, stated with the estimate: 40%; the middle value is on the limit's open side.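

Compound 4 gives only a limit of the assay, > 3900 nM, so its steps from compound 1, compound 2 and compound 3 in this assay cannot be read for size. The compounds shown leave open whether thiophen-2-yl changes the reading relative to 2-(hydroxymethyl)phenyl, 3-(hydroxymethyl)phenyl or 4-hydroxyphenyl.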